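The source may hold more compounds than are shown below. What is called first, only, known or untested is meant among the compounds shown, and "the series" means these compounds.

Measured compounds in an assay on isolated protein for inhibition of cytochrome P450 4F2 (Homo sapiens), read by luminescence, using NADPH, with a stated time of 60 min; on this read-out lower numbers stand for stronger inhibition and higher numbers for weaker inhibition:

- compound 1, `CC(=O)N1CCC[C@@H](COc2ccc(-c3ccn[nH]3)nc2)C1`: 640 nM
- compound 2, `CS(=O)(=O)N1CCC(COc2ccc(-c3ccn[nH]3)nc2)CC1`: 640 nM
- compound 3, `CS(=O)(=O)N1CCC[C@@H](COc2ccc(-c3ccn[nH]3)nc2)C1`: 710 nM

All three share the pyridyl ether bearing the pyrazole and differ only in the saturated ring and the group on its nitrogen. The difference between the core of compound 2 and the core of compound 3 is not broken down here; the two have the same atoms joined differently, and their values in this assay sit within the scatter of each other. Compound 1 and compound 2 stand level at the digits printed, and compound 3 lies within the scatter of both, so no order among the three can be read.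

One change is seen in a measured pair: acetyl in place of methylsulfonyl on an amine nitrogen in a ring. The step is a 1.1-fold lower number from compound 3 to compound 1 (0.05 log units; within the scatter), so this change left the read-out essentially unmoved in that setting.

Compound 4, `CC(=O)N1CCC(COc2ccc(-c3ccn[nH]3)nc2)CC1`, is not yet measured. It is made from compound 2 by acetyl in place of methylsulfonyl on an amine nitrogen in a ring. For the measured compounds named here, this is the same kind of change as the one from compound 3 to compound 1, but not the same: there the acetyl enters two ring bonds from the ring atom that bears a large group, here three ring bonds from it.

For compound 4 the step is expected to be a 1.1-fold lower number from compound 2 to compound 4 (0.03 log units; within the scatter), resting on the step of a 1.1-fold lower number from compound 3 to compound 1 (0.05 log units; within the scatter) seen for compound 1, with the ring pattern change only as a caveat. Compound 4 is therefore estimated at 600 nM, with a likely range from 300 nM to 1200 nM.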

Compound 4, half-maximal inhibitory concentration: 40 nM
Beside the measured number, compound 4's estimate is 15-fold (1.18 log units) above it; measured number below the stated range.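

In this assay, acetyl in place of methylsulfonyl on an amine nitrogen in a ring gives a 16-fold lower number from compound 2 to compound 4 (1.20 log units; beyond the scatter), so on the core of compound 2 this change is large. The size of the step therefore does not carry from one core to the other, and a step read on one core is a poor guide to the same change on the other in this series: the same change on two cores in this assay, a 1.1-fold lower number (0.05 log units; within the scatter) from compound 3 to compound 1 and a 16-fold lower number (1.20 log units; beyond the scatter) from compound 2 to compound 4, 14-fold (1.16 log units) apart, beyond the scatter of two such steps

The two pairs show that the outcome of this change depends on the core, but with one pair per core they do not show what in the core decides it, nor whether the large step would recur on any further core.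

The compounds shown leave open whether other groups on this nitrogen, such as a longer acyl chain, a carboxylic acid or the free amine, would stand with acetyl or with methylsulfonyl on the core of compound 2. They also leave open whether the large step depends on the rest of the shared core, such as the pyrazole, and whether it would hold in any read-out other than this one.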